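Aminopyrimidine Amides and Rho Kinase Two Inhibition

The source may report more compounds than this note shows. Statements on the series, on what has been measured and on what is new or still open speak of the compounds shown alone.

Three aminopyrimidines were tested in an assay on isolated protein for inhibition of Rho-associated protein kinase 2 (Homo sapiens), read by HTRF, tested at 10 uM; on this read-out higher numbers stand for more inhibition at the one concentration tested (going by the name of the read-out) and lower numbers for less inhibition. Compound 1, `Cc1cccc(Oc2ccnc(N3CCN(C(=O)c4c(C)noc4C)CC3)n2)c1`, gives 0% in this assay. Compound 2, `CN(CCCn1ccnc1)C(=O)[C@@H]1CCCN1c1nccc(Nc2ccccc2)n1`, gives 1%. Compound 3, `O=C(C1CCN(c2nccc(Nc3ccccc3)n2)CC1)N1CC[C@@H](O)C1`, gives 0%. Compound 2 holds the highest of the three numbers, but the gaps to compound 1 and to compound 3 both lie within the scatter, so nothing separates the three on these readings.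

The account follows the step from compound 2 to the as yet unmeasured compound 4, `COC[C@@H]1CCCN1C(=O)[C@@H]1CCCN1c1nccc(Nc2ccccc2)n1`. The change is 2-(methoxymethyl)pyrrolidin-1-yl in place of (3-(1H-imidazol-1-yl)propyl)(methyl)amino on a carbonyl carbon. Among the measured compounds shown here, no step between measured compounds is available, so the expectation rests on the flat picture of compound 2 and its neighbours. Since compound 2 gives only 1%, and the two other amides at this position sit in the same range, the step of a number 1 percentage points higher from compound 2 to compound 4 (within the scatter) is expected to be none beyond the scatter. Compound 4 is therefore estimated at 2%, with a range from -8% to 12%.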

Compound 4, a percentage reported as inhibition, at one concentration (the size of the read-out at that concentration, not a potency): 3%
Compound 4: the middle estimate sits 1 percentage points below what was measured; the range from low to high includes it.
By their numbers in this assay, from the lowest: compounds 1, 3, 2 and 4 (each within the scatter of the next).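

Among the compounds shown here, replacing (3-(1H-imidazol-1-yl)propyl)(methyl)amino with 2-(methoxymethyl)pyrrolidin-1-yl on the carbonyl carbon gives a number 2 percentage points higher from compound 2 to compound 4 (within the scatter) in this assay, the first step that can be read at this position. A five-membered aromatic ring with 2 hetero atoms leaves, a five-membered non-aromatic ring with 1 hetero atom and a defined stereocentre enter, and the reading does not move beyond the scatter, so this one exchange leaves the flat picture intact. Nothing shown here bears on why this exchange makes so little difference.

From the compounds shown here alone, whether a primary amine, a carboxylic acid or a longer chain on this carbonyl carbon would move the reading beyond the scatter remains open. So does whether the mirror-image form of 2-(methoxymethyl)pyrrolidin-1-yl would read any differently from the group in compound 4.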